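This account rests on a few compounds, and the source may have more. Where it says the series, first, only, none or still open, it means among the compounds named here.

The shared core is a cyclohexyl carbamate on a phenol that carries a second aromatic ring. In an assay on cell membranes for binding affinity to Fatty-acid amide hydrolase 1 (Rattus norvegicus) (a lower number here means a stronger inhibitor, a higher number a weaker inhibitor), compound 2 `Cc1cccc(-c2cccc(OC(=O)NC3CCCCC3)c2)c1` gives 61.8 nM and sits at the low end of the three numbers measured. Compound 3 `O=C(NC1CCCCC1)Oc1cccc(-c2cccc(F)c2)c1` gives 96.6 nM, and the step of a 1.6-fold higher number from compound 2 to compound 3 (0.19 log units; within the scatter) shows that swapping these two small groups leaves the number essentially unchanged. Compound 1 `NC(=O)c1ccc(-c2cccc(OC(=O)NC3CCCCC3)c2)cc1`, with a carboxamide on the distal ring instead, gives 5910 nM, far weaker than compound 2.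

Compound 4 `O=C(NC1CCCCC1)Oc1cccc(-c2cccc(-c3ccccc3)c2)c1` differs from compound 2 by phenyl in place of methyl on an aromatic carbon. Going by the values given here, no measured step covers a change of this size; the only neighbouring step, from methyl to fluoro, stayed within the scatter, while compound 1 shows that a change on the distal ring can cost a great deal. Compound 4 is therefore expected to land close to compound 2, with the step of a 1.8-fold higher number from compound 2 to compound 4 (0.25 log units; within the scatter) likely within or just beyond the scatter. The estimate for compound 4 in this assay is 110 nM, with a range from 30 nM to 450 nM.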

Compound 4, half-maximal inhibitory concentration: 565 nM
The estimate for compound 4 lay 5.1-fold (0.71 log units) below the measured number; the whole stated range lies below it.
By their numbers in this assay, from the lowest: compounds 2 and 3 (each within the scatter of the next); then compound 4; then compound 1.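

In this assay, the aromatic carbon meta to a large group does not treat every group alike. Methyl and fluoro there give numbers within the scatter of each other, but phenyl gives a 9.1-fold higher number from compound 2 to compound 4 (0.96 log units; beyond the scatter) and a 5.8-fold higher number from compound 3 to compound 4 (0.77 log units; beyond the scatter), so this position accepts one small group in place of another yet responds when a whole aromatic ring enters. Nothing measured here accounts for that loss.

With only methyl, fluoro and phenyl at this carbon, the compounds leave open whether the loss comes from the ring itself or simply from the larger number of atoms. A cyclopropyl ring, a longer chain such as propyl, or an amine or a carboxylic acid at the same carbon would help to separate these possibilities.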